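Swapping an Amide Group on a Weak Antiproliferative Compound

The source may report more compounds than this note shows. Statements on the series, on what has been measured and on what is new or still open speak of the compounds shown alone.

Measured in a functional assay on BaF3 cells (Mus musculus) for antiproliferative activity, read by CCK-8 assay and cell counting, with a stated time of 76 h; a lower number here means a stronger inhibitor, a higher number a weaker inhibitor:
- Compound 1 `COc1cc2nccc(Oc3ccc(Nc4nn(C)cc4C(=O)NCC4CCCO4)cc3)c2cc1C(N)=O`: > 10000 nM
- Compound 2 `COc1cc2nccc(Oc3ccc(Nc4nn(C)cc4C(=O)N4CCCC5CCCCC54)cc3)c2cc1C(N)=O`: 4330 nM

Compound 1 gives > 10000 nM, which is a limit of the assay and not a number. That makes it one of the two measured compounds that sit at the limit of > 10000 nM in this assay, at which 1 of the 2 values shown sits.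

Compound 3 `COc1cc2nccc(Oc3ccc(Nc4nn(C)cc4C(=O)NC4CCCC4)cc3)c2cc1C(N)=O` keeps the core of compound 1 and changes one group: cyclopentyl in place of (oxolan-2-yl)methyl on an amide-type nitrogen. In short, cyclopentyl takes the place of (oxolan-2-yl)methyl on an amide-type nitrogen, so the entering ring is of carbon only.

For the measured compounds named here, only one measured step offers any guide: an at least 2.3-fold lower number from compound 1 to compound 2 (0.36 log units; beyond the scatter). This modest change, beyond the scatter, brought compound 2 to 4330 nM. It swapped a different and larger group on the carbonyl carbon, so it is a loose guide to the new change. A similarly modest shift towards a lower number is therefore expected, although another reading at the limit would be no surprise.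

The expected change is an at least 1.2-fold lower number from compound 1 to compound 3 (0.09 log units; that floor lies within the scatter). For compound 3 the estimated value in this assay is 8000 nM, with an expected range of 3000 nM to 20000 nM.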

Compound 3, half-maximal inhibitory concentration: > 10000 nM
Compound 3: only a limit was reported; the forecaster's own chance of this, stated with the estimate: 45%; middle value at least 1.2-fold (0.09 log units) away from the limit.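

In this assay compound 3 gives > 10000 nM, which is a limit of the assay and not a number. Compound 1 also stands at a limit, so the step between these two cannot be read, and putting cyclopentyl in place of (oxolan-2-yl)methyl on the amide-type nitrogen yields no measurable value; the limit now holds most of the compounds shown: the limit of > 10000 nM in this assay, at which 2 of the 3 values shown sit. For the compounds shown here, the one readable new step is an at least 2.3-fold higher number from compound 2 to compound 3 (0.36 log units; beyond the scatter), which shows that a small carbon-only ring on this nitrogen does not match the larger group on the carbonyl carbon that gave the only measured number so far.

Going by these compounds, how far compound 1 and compound 3 lie past the limit remains unknown, so any true difference between oxolane-bearing and cyclopentyl groups stays hidden. On these data alone, it also remains open whether an amine or a carboxylic acid on the cyclopentyl ring, or a longer chain in its place, would bring the value back within the range of the assay.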